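The source may report more compounds than this note shows. Statements on the series, on what has been measured and on what is new or still open speak of the compounds shown alone.

In a toxicity assay on HepG2 2.2.15 cells (Homo sapiens) for cytotoxicity, read by CellTiter-Glo (on this read-out lower numbers stand for higher toxicity in this test and higher numbers for lower toxicity in this test), compound 1 `CC1CN(C(=O)Nc2cc(F)c(F)c(F)c2)Cc2c(N3CC(C#N)CC3=O)cnn21` gives 115000 nM, compound 2 `O=C1CC(c2cnco2)CN1c1cnn2c1CN(C(=O)Nc1cc(F)c(F)c(F)c1)C(C1CC1)C2` gives 139000 nM, and compound 3 `O=C1NC(c2ccccc2)CN1c1cnn2c1CN(C(=O)Nc1cc(F)c(F)c(F)c1)C(C1CC1)C2` gives 38500 nM. Compound 2 stands at the highest number of the three, within the scatter of compound 1, while the step of a 3.6-fold lower number from compound 2 to compound 3 (0.56 log units; beyond the scatter) lies beyond it. Compound 4 `O=C1CC(Oc2ncc(F)cn2)CN1c1cnn2c1CN(C(=O)Nc1cc(F)c(F)c(F)c1)C(C1CC1)C2` differs from compound 2 by (5-fluoropyrimidin-2-yl)oxy in place of 1,3-oxazol-5-yl on a saturated ring carbon. Going by the values given here, the only measured step at that saturated ring carbon is the one to compound 3, a replacement of a different kind, and nothing measured covers an oxygen-linked six-membered aromatic ring there. Compound 4 is therefore expected to show no step beyond the scatter, a 1.3-fold lower number from compound 2 to compound 4 (0.10 log units; within the scatter). Compound 4 is estimated at 110000 nM, between 45000 nM and 260000 nM.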

Compound 4, half-maximal cytotoxic concentration: 96200 nM
The estimate for compound 4 lay 1.1-fold (0.06 log units) above the measured number; low and high end bracket the measured number.
By their numbers in this assay, from the lowest: compound 3; then compounds 4, 1 and 2 (each within the scatter of the next).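

In this assay the saturated ring carbon, two ring bonds from the ring nitrogen, tolerates a larger group: the change shows a 1.4-fold lower number from compound 2 to compound 4 (0.16 log units; within the scatter) and stays within the scatter. The earlier compounds shown here held no replacement of one aromatic ring by another at this carbon, and the step to compound 3 involved a different ring on the aromatic carbon. No measurement here explains this result.

From the compounds shown here alone, it remains open whether an amine, a carboxylic acid or a longer chain on this saturated ring carbon would move the number beyond the scatter.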